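From 4-chlorophenyl to phenethyl on a sulfur

The source may hold more compounds than are shown below. What is called first, only, known or untested is meant among the compounds shown, and "the series" means these compounds.

Among the measured compounds shown here, in a functional assay on HCT-116 cells (Homo sapiens) for inhibition, read by CCK-8 assay, with a stated time of 72 h, tested at 8 uM (on this read-out higher numbers stand for more inhibition of growth at the one concentration tested and lower numbers for less inhibition of growth), compound 1 (`Nc1ccccc1NC(=O)/C=C/c1ccc(CSc2ccc(Cl)cc2)cc1`) gives 3.27%, the lowest of the three numbers so far. Compound 2 (`CCc1ccc(SCc2ccc(C(=O)Nc3ccccc3N)cc2)cc1`) gives 79.1%, and compound 3 (`Nc1ccccc1NC(=O)c1ccc(CSc2nccc(C(F)(F)F)n2)cc1`) gives 93.1%. Both lie far above compound 1, well beyond the scatter. However, neither differs from compound 1 in a single place, so these values show only how much room exists above it and say nothing about any one group.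

Compound 4 (`Nc1ccccc1NC(=O)/C=C/c1ccc(CSCCc2ccccc2)cc1`) keeps the core of compound 1 and changes one group: phenethyl in place of 4-chlorophenyl on a sulfur. It carries phenethyl in place of 4-chlorophenyl on a sulfur. For the measured compounds named here, no measured pair isolates this exchange, so any expectation for it is loose. Compound 1 sits so low, at 3.27%, that a fall could hardly be seen in this assay, and the only direction open to a visible change is upward. A moderate rise is therefore expected, one that may or may not clear the scatter. The estimated step of a number 18.7 percentage points higher from compound 1 to compound 4 (beyond the scatter) reflects this modest upward expectation. For compound 4 the expected value is 22%, with an estimated range from 3% to 55%.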

Compound 4, percent growth inhibition at one concentration: 10.6%
Estimate against measurement, compound 4: 11.4 percentage points above; the range from low to high includes it.
By their numbers in this assay, from the lowest: compounds 1 and 4 (each within the scatter of the next); then compound 2; then compound 3.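

In this assay, exchanging 4-chlorophenyl for phenethyl on a sulfur gives a number 7.3 percentage points higher from compound 1 to compound 4 (within the scatter), so this exchange does not separate the two compounds on this read-out. Among the compounds shown here, this is the first single-place comparison, and it shows that on the core of compound 1, this exchange at this position leaves no change that can be told from the scatter. The exchange removes the chlorine and brings in a chain on the sulfur in a single step, so the result speaks only for the two changes taken together and cannot be assigned to either, and no measurement at hand bears on why the two compounds fall so close together.

On these data alone, it remains open whether a plain phenyl on the sulfur would behave like 4-chlorophenyl or like phenethyl, which would pull the loss of the chlorine apart from the arrival of the chain. As far as these compounds go, it is also open whether a quite different group on this sulfur, such as an amine-bearing chain or a carboxylic acid, would move the number beyond the scatter on this core.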